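A few compounds are considered here, and "the series" means these few. Any claim that something is new, unique, unknown or untested is made for them only; others in the source may bear on it.

Compound 1 (`N#CCCN(Cc1cccs1)S(=O)(=O)c1ccc(Cl)cc1`), compound 2 (`N#CCCN(Cc1cccs1)S(=O)(=O)c1ccc(Br)cc1`) and compound 3 (`N#CCCN(Cc1cccs1)S(=O)(=O)c1ccc([N+](=O)[O-])cc1`) share one core and differ in a single group. In an ADME assay on MDCK cells (Canis lupus familiaris) for cytotoxicity, read by MTT assay, with a stated time of 24 h (a lower number here means that less compound is tolerated, a higher number that more compound is tolerated), compound 1 gives > 195000 nM, which is a limit of the assay. Compound 2 gives > 173000 nM, also a limit. Compound 3 gives > 189000 nM, again a limit, so it has no exact number. The measured exchanges are a step that the two limits leave unreadable from compound 1 to compound 2, a step that the two limits leave unreadable from compound 1 to compound 3 and a step that the two limits leave unreadable from compound 2 to compound 3. Compound 4 (`CC(=O)c1ccc(S(=O)(=O)N(CCC#N)Cc2cccs2)cc1`) carries acetyl in place of nitro on an aromatic carbon, para to a large group: acetyl in place of nitro on an aromatic carbon. The measured steps offer no size to carry over, so none beyond the scatter is expected, and the estimated step is a step that the limit leaves unreadable from compound 3 to compound 4. For compound 4 the expected value is 190000 nM, with an estimated range from 120000 nM to 260000 nM.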

Compound 4, half-maximal cytotoxic concentration: > 191000 nM
Compound 4 was reported as a limit; the forecaster's own chance of this, stated with the estimate: 85%; middle value at least 1.0-fold (0.00 log units) away from the limit.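

In this assay compound 4 gives > 191000 nM as a limit, so its steps from compound 1, compound 2 and compound 3 cannot be read. The compounds shown leave open where the half-maximal cytotoxic concentration of any of the four lies, and whether chloro, bromo, nitro and acetyl differ at all.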